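Adding a methyl to the aromatic ring of compound 1

This account rests on a few compounds, and the source may have more. Where it says the series, first, only, none or still open, it means among the compounds named here.

Measured so far in a functional assay on HepG2 cells (Homo sapiens) for cytotoxicity, read by MTT assay, with a stated time of 72 h; on this read-out higher numbers stand for weaker inhibition and lower numbers for stronger inhibition:
compound 1 `O=C1C=CCC/C1=C\C=C\c1ccccc1` gives 7100 nM
compound 2 `CC(=C\c1ccccc1)/C=C1\CCC=CC1=O` gives 4600 nM

Among the compounds with values here, only these two compounds have numbers, and compound 1 stands within the scatter of its one neighbour, as the step of a 1.5-fold lower number from compound 1 to compound 2 (0.19 log units; within the scatter) makes plain. Compound 3 `Cc1ccc(/C=C/C=C2\CCC=CC2=O)cc1` has not yet been measured. Its difference from compound 1 is methyl in place of hydrogen on an aromatic carbon and the rest of the core stays the same. This is a methyl in place of hydrogen on an aromatic carbon, para to a large group.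

Within the data shown here, the one measured step bears on this only loosely. Among the measured compounds shown here, it also brings a methyl in place of hydrogen, but on a double-bonded chain carbon rather than an aromatic carbon, and no measured compound carries anything new on the aromatic ring. The expectation therefore rests on compound 2 at 4600 nM and on that step staying within the scatter. No change beyond the scatter is expected, and the estimated step is a 1.3-fold lower number from compound 1 to compound 3 (0.11 log units; within the scatter) with no firm direction. For compound 3 the estimated value is 5500 nM with an expected range from 2500 nM to 12000 nM in this assay when it is measured.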

Compound 3, half-maximal inhibitory concentration: 8600 nM
Estimate against measurement, compound 3: 1.6-fold (0.19 log units) below; low and high end bracket the measured number.
By their numbers in this assay, from the lowest: compounds 2, 1 and 3 (each within the scatter of the next).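

Within the data shown here, with methyl in place of hydrogen on an aromatic carbon, para to a large group, this assay records a 1.2-fold higher number from compound 1 to compound 3 (0.08 log units; within the scatter), and this is the first reading of any change on the aromatic ring of the shared core. The earlier step, a 1.5-fold lower number from compound 1 to compound 2 (0.19 log units; within the scatter), concerned only a methyl on a double-bonded chain carbon, so the new result extends the finding to a second place: a single added methyl on the six-membered aromatic ring also stays within the scatter, and this one step gives no direction for the change. Nothing available explains why this step is so small, and no measurement of any property of these compounds bears on it.

The compounds shown leave open whether a group other than methyl at this same place, such as a methoxy group, a chlorine atom, an amine or a carboxylic acid, would move the number beyond the scatter. They also leave open whether a longer chain there, or a methyl on another carbon of the aromatic ring, would give a step of similar size.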